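Swapping the Aryl Group in a Muscle-Active Compound

The source may hold more compounds than are shown below. What is called first, only, known or untested is meant among the compounds shown, and "the series" means these compounds.

Among the compounds with values here, compound 1 `COC(=O)C1=C(C)N=C(C)/C(=C(\O)OC)C1c1cccc(OC)c1` was tested in a functional assay (muscle tissue) with Cavia porcellus as the target (a lower number here means that less compound is needed, a higher number that more compound is needed for the effect), and gives 191 nM, the lowest of the two numbers known so far. Compound 2 `COC(=O)C1=C(C)N=C(C)/C(=C(\O)OC)C1c1cc(OC)c(OC)cc1OC` gives 1000000 nM in this assay, a far larger amount, well beyond the usual scatter. Compound 3 `COC(=O)C1=C(C)N=C(C)/C(=C(\O)OC)C1c1ccc(I)cc1` has not yet been measured. It differs from compound 1 by 4-iodophenyl in place of 3-methoxyphenyl on a saturated ring carbon. Within the data shown here, no step between measured compounds matches this change, so the expectation rests on compound 1 alone. From compound 1, a moderate rise in the number is expected, a 5.2-fold higher number from compound 1 to compound 3 (0.72 log units; beyond the scatter). Compound 3 is therefore estimated to give 1000 nM in this assay, within a range from 150 nM to 10000 nM.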

Compound 3, half-maximal effective concentration: 22900 nM
Compound 3: the middle estimate sits 23-fold (1.36 log units) below what was measured, and the stated range ends below it.
By their numbers in this assay, from the lowest: compound 1; then compound 3; then compound 2.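

Putting 4-iodophenyl in place of 3-methoxyphenyl on the saturated ring carbon has a large effect in this assay, with a 120-fold higher number from compound 1 to compound 3 (2.08 log units; beyond the scatter). So with the core of compound 1 left unchanged, this single swap of the aryl group is enough to move the number far beyond the scatter. Nothing available here explains why the number rises.

The swap changes both the group on the phenyl ring and where it sits, so the two effects cannot yet be told apart. A 3-iodophenyl or 4-methoxyphenyl group at this position would separate them.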